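Fluoro for methyl on the shared core: stability notes

The compounds below may be only part of what the source reports. "The series", "measured", "known", "first", "only" and "open" are said of these compounds alone.

Measured compounds:
compound 1 `C[C@H](Nc1ncnc2[nH]cnc12)c1cc2ccccn2c(=O)c1-c1ccccc1`, 93%
compound 2 `Cc1ccc2cc([C@H](C)Nc3ncnc4[nH]cnc34)c(-c3ccccc3)c(=O)n2c1`, "not determined" (no result reported)
compound 3 `Cc1ccc2cc([C@H](C)Nc3ncnc(N)c3C#N)c(-c3ccccc3)c(=O)n2c1`, "not determined" (no result reported)

The read-out is an ADME assay on microsomes from liver (Rattus norvegicus), read by LC-MS, using NADPH, with a stated time of 30 min, tested at 1 uM; on this read-out lower numbers stand for a less stable compound and higher numbers for a more stable compound. Compound 1 gives 93% in this assay. Going by the values given here, compound 2 has no number in this assay, and compound 3 likewise has none, so compound 2 cannot be placed against either of them; the only number in the set belongs to compound 1.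

The step from compound 2 goes to compound 4 `C[C@H](Nc1ncnc2[nH]cnc12)c1cc2ccc(F)cn2c(=O)c1-c1ccccc1`: fluoro in place of methyl on an aromatic carbon. Among the compounds with values here, no measured pair shows a comparable change, so the size of this step is unknown. The expectation for compound 4 is a value near that of compound 1, 93%, with no step beyond the scatter anticipated. Compound 4 is estimated at 88%, within 70% to 100%.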

Compound 4, percent of the compound remaining: 95%
For compound 4 the middle estimate is 7 percentage points below the measured one; the measured number falls inside the stated range.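

On the shared core, fluoro in place of hydrogen on this aromatic carbon, two atoms from the ring nitrogen, gives a number 2 percentage points higher from compound 1 to compound 4 (within the scatter) in this assay, so the high stability of compound 1 is kept with fluoro at this position. The step between compound 2 and compound 4 cannot be read: compound 2 has no single number. Nothing available explains the flat result.

Open, as far as these compounds go, is whether methoxy or an amine on this carbon would keep the same stability in this assay. Also open, from the compounds shown here alone, is whether fluoro at this position would do the same on the core of compound 3.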